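A few compounds are considered here, and "the series" means these few. Any claim that something is new, unique, unknown or untested is made for them only; others in the source may bear on it.

Working notes on the series. Going by the values given here, compound 3 `C[C@H]1CCCN1c1c(C#N)c2c(N)ncnc2n1C` sits second highest of the three numbers so far in an assay on isolated protein for binding affinity to Leucine-rich repeat serine/threonine-protein kinase 2 variant G2019S (Homo sapiens), read by TR-FRET and LanthaScreen, with a stated time of 2 h; on this read-out lower numbers stand for stronger inhibition and higher numbers for weaker inhibition: compound 3 gives 212 nM. Its nearest neighbour is compound 2 `Cc1cn(C)nc1Nc1cc2c(c(N)n1)c(C#N)c(N1CCC[C@H]1C)n2C`, which in this assay gives 75 nM; the furthest is compound 1 `Cn1c(-n2cccc2)c(C#N)c2c(N)ncnc21`, which gives 1980 nM. Among the compounds with values here, the one measured step that touches compound 3 directly is a 9.3-fold lower number from compound 1 to compound 3 (0.97 log units; beyond the scatter).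

The next compound, compound 4 `Cn1c(N)c(C#N)c2c(N)ncnc21`, differs from compound 3 in one place: amino in place of 2-methylpyrrolidin-1-yl on an aromatic carbon. The exchange sits on an aromatic carbon of a five-membered aromatic ring with 1 nitrogen, part of a fused system of two rings.

Within the data shown here, the only step that bears on this is the one from compound 1 to compound 3, where a five-membered non-aromatic ring replaced an aromatic one at the same carbon and the number fell clearly. Here the ring leaves altogether and a single nitrogen enters, so the direction of that step gives no direct guide; a six-heavy-atom group shrinks to one atom, and a loss of potency beyond the scatter is the more likely outcome. The step from compound 3 to compound 4 is therefore expected at a 7.1-fold higher number from compound 3 to compound 4 (0.85 log units; beyond the scatter). Compound 4 is estimated at 1500 nM, with a range from 400 nM to 6000 nM.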

Compound 4, inhibition constant: 589 nM
Beside the measured number, compound 4's estimate is 2.5-fold (0.41 log units) above it; measured number inside the range.
By their numbers in this assay, from the lowest: compound 2; then compound 3; then compound 4; then compound 1.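

At this aromatic carbon, this assay shows that the ring of 2-methylpyrrolidin-1-yl and its defined stereocentre can go entirely at a modest cost: amino in its place gives a 2.8-fold higher number from compound 3 to compound 4 (0.44 log units; beyond the scatter), a step beyond the scatter but smaller than the one separating the two ring groups. Amino also improves on 1H-pyrrol-1-yl, with a 3.4-fold lower number from compound 1 to compound 4 (0.53 log units; beyond the scatter), so the single-atom group falls between the two ring groups and the number at this position does not simply follow group size across these three compounds. No measurement shown accounts for this order.

Open, on these data alone, is how the numbers would run through intermediate groups at this carbon, such as methylamino, dimethylamino or pyrrolidin-1-yl without its methyl, and how the opposite configuration of the 2-methylpyrrolidin-1-yl group would compare. Also open, as far as these compounds go, is whether amino in place of 2-methylpyrrolidin-1-yl would give a step of similar size on the core of compound 2, which differs from compound 3 in more than one place.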